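The source may report more compounds than this note shows. Statements on the series, on what has been measured and on what is new or still open speak of the compounds shown alone.

In a functional assay on HepG2 cells (Homo sapiens) for inhibition, read by MTT assay, with a stated time of 72 h (a higher number here means a weaker inhibitor, a lower number a stronger inhibitor), compound 1 `Cc1ccc(-c2nnc(SCCCN3CCN(c4nc5ccccc5s4)CC3)o2)cc1` gives 96700 nM and compound 2 `CC(C)(C)Oc1ccc(-c2nnc(SCCCN3CCN(c4nc5ccccc5s4)CC3)o2)cc1` gives 202000 nM, the higher of the two numbers, which makes compound 2 the weaker inhibitor. Compound 3 `Oc1ccc(-c2nnc(SCCCN3CCN(c4nc5ccccc5s4)CC3)o2)cc1` differs from compound 2 in one place: hydrogen in place of tert-butyl on an oxygen on an aromatic ring, so tert-butoxy becomes hydroxy. Among the measured compounds shown here, only one measured step bears on this, the modest 2.1-fold higher number from compound 1 to compound 2 (0.32 log units; beyond the scatter), which also involves tert-butoxy. Taking that group away may give back a step of similar size. The expected change is a 1.8-fold lower number from compound 2 to compound 3 (0.26 log units; within the scatter), a modest move towards a lower number. Compound 3 is estimated at 110000 nM, with an expected range of 40000 nM to 250000 nM.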

Compound 3, half-maximal inhibitory concentration: 364000 nM
Estimate against measurement, compound 3: 3.3-fold (0.52 log units) below; measured number outside the range, above it.
By their numbers in this assay, from the lowest: compound 1; then compounds 2 and 3 (each within the scatter of the next).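

Removing the tert-butyl from the oxygen does not bring the number back towards compound 1: a 1.8-fold higher number from compound 2 to compound 3 (0.26 log units; within the scatter), so tert-butoxy and hydroxy cannot be told apart at this position. Methyl is the group that stands apart, with a 3.8-fold higher number from compound 1 to compound 3 (0.58 log units; beyond the scatter). Nothing measured here gives a reason for this difference.

From the compounds shown here alone, it remains open whether methoxy, with a single carbon on the same oxygen, would group with methyl or with hydroxy and tert-butoxy. An amine or a carboxylic acid in this place also remains untested among the compounds shown here.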